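Adding a Fluoro Group to a Pyrazole Urea Antagonist

A few compounds are considered here, and "the series" means these few. Any claim that something is new, unique, unknown or untested is made for them only; others in the source may bear on it.

Compounds measured so far:
compound 1, `CC(=O)n1ncc2c(NC(=O)NCc3cc(C(F)(F)F)nn3-c3cccc(Cl)c3)cccc21`, 17.4 nM;
compound 2, `CC(=O)n1ncc2c(NC(=O)NCc3cc(C(C)(C)C)nn3-c3cccc(Cl)c3)cccc21`, 29.5 nM;
compound 3, `Cn1ncc2c(NC(=O)NCc3cc(C(F)(F)F)nn3-c3cccc(F)c3)cccc21`, 7 nM.

In an assay on CHO-K1 cells for antagonist activity at transient receptor potential cation channel subfamily V member 1 (Homo sapiens), read by FLIPR and calcium flux, with a stated time of 6 min (a lower number here means a stronger inhibitor, a higher number a weaker inhibitor), compound 3 holds the lowest number of the three measured compounds. Compound 1 stands next to it with a higher number, and compound 2 lies furthest away. Going by the values given here, the one measured step, a 1.7-fold higher number from compound 1 to compound 2 (0.23 log units; within the scatter), concerns a change at a different position and falls within the scatter, so it says nothing about the change now considered.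

Compound 4, `Cn1ncc2c(NC(=O)NCc3cc(C(F)(F)F)nn3-c3ccc(F)c(F)c3)cccc21`, differs from compound 3 by fluoro in place of hydrogen on an aromatic carbon. Among the compounds with values here, no measured pair shows what this change does. Compound 4 is therefore expected to stay close to compound 3, with no change at the digits printed from compound 3 to compound 4 (within the scatter), giving an estimated 7 nM in a range from 2.5 nM to 20 nM.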

Compound 4, inhibition constant: 4.9 nM
For compound 4 the middle estimate is 1.4-fold (0.15 log units) above the measured one; the range from low to high includes it.
By their numbers in this assay, from the lowest: compounds 4 and 3 (each within the scatter of the next); then compounds 1 and 2 (each within the scatter of the next).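

Going by these compounds alone, the step to 3,4-difluorophenyl is a 1.4-fold lower number from compound 3 to compound 4 (0.15 log units; within the scatter) in this assay and gives the first measured reading of this change. A fluoro group in place of hydrogen at this position, ortho to a fluoro group and para to a large group, is thus accepted without a change beyond the scatter. No available evidence explains this result.

On these data alone, whether a methoxy group or an amine at this position would also leave the number within the scatter remains open. So does whether this fluoro group would behave alike with tert-butyl in place of trifluoromethyl.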